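The source may report more compounds than this note shows. Statements on the series, on what has been measured and on what is new or still open speak of the compounds shown alone.

In a functional assay on PC-9 cells (Homo sapiens) for inhibition, read by MTT assay, with a stated time of 72 h (a higher number here means a weaker inhibitor, a lower number a stronger inhibitor), compound 1 `Cc1cc(Nc2cc(-c3ccccc3)[nH]n2)n2nc(SCc3ccc(Br)cc3)nc2n1`, with a 4-bromophenyl on a saturated chain carbon bound to a sulfur, gives 4760 nM. Compound 2 `C#CCSc1nc2nc(C)cc(Nc3cc(-c4ccccc4)[nH]n3)n2n1` reads > 50000 nM, which is a limit of the assay and not a number. Compound 3 `C=CCSc1nc2nc(C)cc(Nc3cc(-c4ccccc4)[nH]n3)n2n1` reads > 50000 nM, which is also a limit. Compound 3 therefore has no number of its own and stands at the limit of > 50000 nM in this assay, at which 2 of the 3 values shown sit.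

Compound 4 `Cc1cc(Nc2cc(-c3ccccc3)[nH]n2)n2nc(SCc3ccc(C(F)(F)F)cc3)nc2n1` differs from compound 3 by 4-(trifluoromethyl)phenyl in place of vinyl on a saturated chain carbon bound to a sulfur. Within the data shown here, two measured steps bear on this change. One is an at least 10-fold higher number from compound 1 to compound 3 (1.02 log units; beyond the scatter), and the other is an at least 10-fold higher number from compound 1 to compound 2 (1.02 log units; beyond the scatter). Both are large, and in both the 4-bromophenyl gives way to a group without a ring. The step that the two limits leave unreadable from compound 2 to compound 3 adds nothing further.

Read in reverse, these steps lead to the expectation of a large move toward a lower number in this assay, since compound 4 regains a substituted phenyl in the place where compound 1 shows 4760 nM. The expected size is an at least 10-fold lower number from compound 3 to compound 4 (1.00 log units; beyond the scatter). For compound 4 the estimated value is 5000 nM, with an expected range from 1500 nM to 20000 nM.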

Compound 4, half-maximal inhibitory concentration: 4240 nM
Compound 4: the middle estimate sits 1.2-fold (0.07 log units) above what was measured, within the range that was stated.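

In this assay, 4-(trifluoromethyl)phenyl in place of vinyl gives an at least 11-fold lower number from compound 3 to compound 4 (1.07 log units; beyond the scatter) and in place of ethynyl gives an at least 11-fold lower number from compound 2 to compound 4 (1.07 log units; beyond the scatter) and both steps start from a limit of the assay, not a number: the limit of > 50000 nM in this assay, at which 2 of the 4 values shown sit. Until now only the 4-bromophenyl of compound 1 had given a measured number at this place, on a saturated chain carbon bound to a sulfur, and compound 4 shows that a second substituted phenyl there does so too. Trifluoromethyl in place of bromo on an aromatic carbon gives a 1.1-fold lower number from compound 1 to compound 4 (0.05 log units; within the scatter) and so, in this assay, the two substituents cannot be told apart, which ties the large steps to the change from a chain without a ring to a substituted benzyl in these four compounds only.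

The compounds shown leave open how a benzyl with no substituent, or one carrying a nitrile or a methoxy group, would read, and how an amine or a carboxylic acid at the end of a longer chain would read at this place. The step between compound 2 and compound 3 cannot be read, as both are limits.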